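The source may hold more compounds than are shown below. What is called first, only, known or untested is meant among the compounds shown, and "the series" means these compounds.

Measured in a functional assay on MC-38 cells (Mus musculus) for antiproliferative activity; a lower number here means a stronger inhibitor, a higher number a weaker inhibitor:
- compound 1 `N#Cc1c[nH]c2c(NS(=O)(=O)c3ccc(C(N)=O)cc3)cccc12`: 0.68 ug/mL
- compound 2 `COc1ccc(S(=O)(=O)Nc2cccc3c(Cl)c[nH]c23)cc1`: 0.2 ug/mL
- compound 3 `N#Cc1ccc(S(=O)(=O)Nc2cccc3c(Cl)c[nH]c23)cc1`: 0.13 ug/mL

Compound 3, at 0.13 ug/mL, lies within the usual scatter of compound 2, at 0.2 ug/mL, while compound 1 has a clearly higher number, 0.68 ug/mL. The next structure, compound 4 `NC(=O)c1ccc(S(=O)(=O)Nc2cccc3c(Cl)c[nH]c23)cc1`, has carbamoyl in place of cyano on an aromatic carbon.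

Within the data shown here, one measured step bears on this place: a 1.5-fold lower number from compound 2 to compound 3 (0.19 log units; within the scatter), a swap of methoxy for cyano that stayed within the scatter. Compound 1 also carries carbamoyl, but its core differs, so it offers only a loose guide. The estimated change is small, a 1.5-fold higher number from compound 3 to compound 4 (0.19 log units; within the scatter), and is not expected to exceed the scatter. Compound 4 is expected at 0.2 ug/mL, with an estimated range of 0.08 ug/mL to 0.5 ug/mL.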

Compound 4, half-maximal inhibitory concentration: 0.19 ug/mL
Estimate against measurement, compound 4: 1.1-fold (0.02 log units) above; the range from low to high includes it.
By their numbers in this assay, from the lowest: compounds 3, 4 and 2 (each within the scatter of the next); then compound 1.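

Cyano, methoxy and carbamoyl, on an aromatic carbon para to a large group, all give numbers within the scatter in this assay: a 1.5-fold higher number from compound 3 to compound 4 (0.16 log units; within the scatter), and a 1.1-fold lower number from compound 2 to compound 4 (0.02 log units; within the scatter). With carbamoyl held fixed, chloro in place of cyano on an aromatic carbon of the core gives a step beyond the scatter, a 3.6-fold lower number from compound 1 to compound 4 (0.55 log units; beyond the scatter). No measurement shown here explains either result.

As far as these compounds go, it remains open whether a carboxylic acid or an amine at this place would also stay within the scatter.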